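A few compounds are considered here, and "the series" means these few. Any claim that something is new, unique, unknown or untested is made for them only; others in the source may bear on it.

Measured in a functional assay on MCF7 cells (Homo sapiens) for cytotoxicity, read by MTT assay, with a stated time of 48 h (a higher number here means a weaker inhibitor, a lower number a stronger inhibitor), so far
Compound 1 `CCN(CC)C(=S)SC(CC(C)=O)c1ccccc1` gives 23000 nM
Compound 2 `CCN(CC)C(=S)SC(CC(=O)c1ccc(Br)cc1)c1ccccc1` gives 5000 nM
Compound 3 `CCN(CC)C(=S)SC(CC(=O)c1ccc(Cl)c(Cl)c1)c1ccccc1` gives 4500 nM

Compound 3 sits at the low end of these numbers, with a 1.1-fold lower number from compound 2 to compound 3 (0.05 log units; within the scatter) as its nearest step and a 5.1-fold lower number from compound 1 to compound 3 (0.71 log units; beyond the scatter) as its furthest. Compound 4 `CCN(CC)C(=S)SC(CC(=O)c1ccc(Cl)cc1)c1ccccc1` is related to compound 3 by hydrogen in place of chloro on an aromatic carbon in the change from 3,4-dichlorophenyl to 4-chlorophenyl. The closest evidence is a 1.1-fold lower number from compound 2 to compound 3 (0.05 log units; within the scatter) on exchanging 4-bromophenyl for 3,4-dichlorophenyl, whereas a 4.6-fold lower number from compound 1 to compound 2 (0.66 log units; beyond the scatter) concerns replacing methyl on the carbonyl carbon, a change not undone in compound 4. No step beyond the scatter is therefore expected in this assay and the estimated 1.2-fold higher number from compound 3 to compound 4 (0.09 log units; within the scatter) stays small. The estimate for compound 4 is 5500 nM with an expected range from 2800 nM to 11000 nM in this measurement.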

Compound 4, half-maximal inhibitory concentration: 40 nM
Beside the measured number, compound 4's estimate is 140-fold (2.14 log units) above it; measured number outside the range, below it.
By their numbers in this assay, from the lowest: compound 4; then compounds 3 and 2 (each within the scatter of the next); then compound 1.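

In this assay, hydrogen in place of chloro on the aromatic carbon gives a 110-fold lower number from compound 3 to compound 4 (2.05 log units; beyond the scatter), whereas the earlier exchange of 4-bromophenyl for 3,4-dichlorophenyl stayed within the scatter, so this aryl group is far less tolerant of change than those compounds showed. Chloro in place of bromo gives a 130-fold lower number from compound 2 to compound 4 (2.10 log units; beyond the scatter), and 4-chlorophenyl in place of methyl on the carbonyl carbon gives a 580-fold lower number from compound 1 to compound 4 (2.76 log units; beyond the scatter), well beyond the earlier aryl-for-methyl steps. Nothing available explains these steps. From the compounds shown here alone, what a 4-fluorophenyl, a 4-methoxyphenyl or an unsubstituted phenyl group on the carbonyl carbon would give remains open.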